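The source may hold more compounds than are shown below. What is called first, only, known or untested is meant among the compounds shown, and "the series" means these compounds.

Measured so far in an ADME assay on a cell-free system (plasma, Rattus norvegicus) for metabolic stability, read by LC-MS, with a stated time of 60 min, tested at 100 uM; a higher number here means that more of the compound is left, a lower number that less of the compound is left:
compound 1 `Cc1c(OCCCCOCOc2ccc(C(=O)O)cc2)ccc(C(=O)CC2CCCC2)c1O`: 100%
compound 2 `CCCC(=O)c1ccc(OCCCCOc2cc(C(=O)O)ccc2OC)c(C)c1O`: 78%
compound 3 `Cc1c(OCCCCOc2ccccc2C(=O)O)ccc(C(=O)CC(C)C)c1C`: 99%

Compound 1, at 100%, and compound 3, at 99%, lie within the usual scatter of each other. Compound 2, at 78%, stands lower than both, beyond that scatter, so compound 1 sits at the top of this small set without being clearly ahead of compound 3.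

The next compound to be tested is compound 4 `Cc1c(OCCCCOc2ccc(C(=O)O)c(Cl)c2)ccc(C(=O)CC2CCCC2)c1O`. It differs from compound 1 in one place, on an oxygen on a saturated carbon, where 4-carboxy-3-chlorophenyl stands in place of (4-carboxyphenoxy)methyl: 4-carboxy-3-chlorophenyl in place of (4-carboxyphenoxy)methyl on an oxygen on a saturated carbon.

Going by the values given here, no measured pair in this set isolates a single change, so the evidence is thin. Compound 2, at 78%, shows that lower values do occur among these structures, so a small loss is more likely than a gain in this assay. The expected step of a number 6 percentage points lower from compound 1 to compound 4 (within the scatter) stays within the usual scatter. The estimate for compound 4 is 94%, with an expected range from 80% to 100%.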

Compound 4, percent of the compound remaining: 97%
Compound 4: the middle estimate sits 3 percentage points below what was measured, and the stated range covers the measured number.
By their numbers in this assay, from the lowest: compound 2; then compounds 4, 3 and 1 (each within the scatter of the next).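

In this assay, going by these compounds alone, placing 4-carboxy-3-chlorophenyl in place of (4-carboxyphenoxy)methyl on an oxygen on a saturated carbon gives a number 3 percentage points lower from compound 1 to compound 4 (within the scatter), the first step in this set that isolates a single change. Repeat measurements could not tell these two compounds apart, so on this one comparison the position accepts a chlorine-bearing group in place of the longer (4-carboxyphenoxy)methyl without a clear difference in how much compound is left. No measurement here explains this outcome.

This single pair cannot separate the effect of the chlorine from that of the rest of the exchange. As far as these compounds go, how a methyl ester or an amide in place of the carboxylic acid would fare at this position also stays open.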